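A few compounds are considered here, and "the series" means these few. Any claim that something is new, unique, unknown or untested is made for them only; others in the source may bear on it.

Measured so far:
compound 2, `COc1ccc(-c2cccc(C(=O)N(C)CCN(C)C)c2)cc1S(=O)(=O)Nc1cccc(NCCNC(=O)c2cccc(C)c2)c1`: 293 nM
compound 1, `COc1ccc(-c2cccc(C(=O)N(C)C)c2)cc1S(=O)(=O)Nc1cccc(N2CCN(C(=O)c3cccc(C)c3)CC2)c1`: > 10000 nM

In a functional assay on CHO-RD-HGA16 cells for agonist activity at Orexin receptor type 2 (Homo sapiens), read by fluorescence and calcium flux, with a stated time of 30 min (a lower number here means that less compound is needed, a higher number that more compound is needed for the effect), compound 2 gives 293 nM. Compound 1 does not give a number at all; it sits at the limit of this assay, > 10000 nM, and that value is only a limit (the limit of > 10000 nM in this assay, at which 1 of the 2 values shown sits). Among the compounds with values here, compound 2 is therefore the only real number among the two values shown, and the single point from which any expectation can start.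

Compound 3 is `COc1ccc(-c2cccc(C(=O)NCc3ccccn3)c2)cc1S(=O)(=O)Nc1cccc(NCCNC(=O)c2cccc(C)c2)c1`. It differs from compound 2 in one place: ((pyridin-2-yl)methyl)amino in place of (2-(dimethylamino)ethyl)(methyl)amino on a carbonyl carbon. In plain words, a flexible chain bearing a second amine gives way to a ring-bearing group that carries an amide hydrogen, on the same carbonyl carbon. Within the data shown here, no pair of measured compounds shows what such a change does here, so the size and direction of the step are uncertain. The expected step is a moderate loss, a higher number than for compound 2, of a size that may just exceed the usual scatter: a 2.4-fold higher number from compound 2 to compound 3 (0.38 log units; beyond the scatter). Compound 3 is estimated at 700 nM, with a range from 150 nM to 4000 nM.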

Compound 3, half-maximal effective concentration: 464 nM
Estimate against measurement, compound 3: 1.5-fold (0.18 log units) above; the measured number falls inside the stated range.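

On this carbonyl carbon, this assay records a 1.6-fold higher number from compound 2 to compound 3 (0.20 log units; within the scatter), so this read-out does not separate the two groups. The position therefore accepts two quite different groups while still giving a measured number: the flexible (2-(dimethylamino)ethyl)(methyl)amino group, which has a second amine and no amide hydrogen, and the ring-bearing ((pyridin-2-yl)methyl)amino group, which has an amide hydrogen, so at this position, in this pair, neither the second amine of the chain nor the absence of an amide hydrogen is needed for a measured number. Nothing shown explains why the two groups read so much alike.

From the compounds shown here alone, two groups at one position give only a narrow view, and it remains open whether a carboxylic acid, a simple primary amide or a longer chain ending in a morpholine ring would also be accepted on this carbonyl carbon. Going by these compounds, it is equally open whether the ring nitrogen of the pyridine matters, which a benzylamino group, with a plain benzene ring in its place, would help to show.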